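Stereoisomer notes: the mirror image of compound 2

The compounds below may be only part of what the source reports. "The series", "measured", "known", "first", "only" and "open" are said of these compounds alone.

Measured in a functional assay on QGY cells (Homo sapiens) for cytotoxicity, read by MTT assay, with a stated time of 48 h; a higher number here means a weaker inhibitor, a lower number a stronger inhibitor:
- compound 1 `CCOC(=O)[C@@]1(C(=O)Nc2ccccc2)C[C@@H]1c1cc(OC)c(OC)c(OC)c1`: > 100000 nM (a limit)
- compound 2 `CCOC(=O)[C@]1(C(=O)Nc2ccccc2)C[C@@H]1c1cc(OC)c(OC)c(OC)c1`: 38100 nM

Among the measured compounds shown here, compound 2 holds the only actual number in this assay, at 38100 nM. For compound 1 the reading of > 100000 nM is a limit of the assay and not a number.

For the measured compounds named here, the one measured step is an at least 2.6-fold lower number from compound 1 to compound 2 (0.41 log units; beyond the scatter). It comes with the fact that compounds 1 and 2 differ only in the configuration as drawn.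

Compound 3 `CCOC(=O)[C@@]1(C(=O)Nc2ccccc2)C[C@H]1c1cc(OC)c(OC)c(OC)c1` is the next stereoisomer: the two compounds have the same atoms and bonds and differ only in configuration as drawn: 2 of 2 stereo elements differ (all stereocentres are inverted: mirror images); a stereocentre at a saturated ring carbon is drawn R in compound 2 and S in compound 3; a stereocentre at a saturated ring carbon is drawn R in compound 2 and S in compound 3. Here all stereocentres are inverted, not just one, and no measured step covers such a change. The expectation rests on compound 2 at 38100 nM and on an at least 2.6-fold lower number from compound 1 to compound 2 (0.41 log units; beyond the scatter). A modest move towards a higher number is expected in this assay, and the reading may reach the limit.

The estimated step is a 1.7-fold higher number from compound 2 to compound 3 (0.23 log units; within the scatter). For compound 3 the expected value is 65000 nM, with an estimated range of 20000 nM to 100000 nM.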

Compound 3, half-maximal inhibitory concentration: 48700 nM
The estimate for compound 3 lay 1.3-fold (0.13 log units) above the measured number, and the stated range covers the measured number.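

In this assay, inverting both stereocentres gives a 1.3-fold higher number from compound 2 to compound 3 (0.11 log units; within the scatter), so the mirror-image pair is not separated by this read-out. Compound 1 reads > 100000 nM, which is a limit of the assay and not a number. Compound 3 also stands apart from that limit, with an at least 2.0-fold lower number from compound 1 to compound 3 (0.31 log units; beyond the scatter), so the separation seen earlier for compound 2 is not specific to one mirror image, and this goes with configuration alone: the fact that compounds 1 and 3 differ only in the configuration as drawn

The compounds shown leave open whether the match between compound 2 and compound 3 persists when the ethyl ester is replaced by a carboxylic acid or a primary amide. They also leave open whether an amine in place of a methoxy group changes these readings or the way they depend on configuration.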